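The source may hold more compounds than are shown below. What is called first, only, known or untested is meant among the compounds shown, and "the series" means these compounds.

Compound 1 `COc1ccc2sc(/C=C\c3cc(OC)c(OC)c(OC)c3)cc2c1` offers no guide here: in a functional assay on A2780 cells (Homo sapiens) for antiproliferative activity, read by MTT assay, with a stated time of 72 h (a lower number here means a stronger inhibitor, a higher number a weaker inhibitor), the entry for compound 1 reads "not determined" (no result reported). Compound 2 `COc1ccsc1/C=C\c1cc(OC)c(OC)c(OC)c1` gives > 1000 nM in this assay, and this is a limit of the assay, not a number. That leaves compound 2 without a single value, so the only anchor is the limit of > 1000 nM in this assay, at which 1 of the 2 values shown sits.

Compound 3 `COc1csc(/C=C\c2cc(OC)c(OC)c(OC)c2)c1` holds the same atoms as compound 2, joined differently. The change is 4-methoxythiophen-2-yl in place of 3-methoxythiophen-2-yl on a double-bonded chain carbon bound to a double-bonded chain carbon: a 4-methoxythiophen-2-yl in place of a 3-methoxythiophen-2-yl, on a double-bonded chain carbon bound to a double-bonded chain carbon. Within the data shown here, no step between measured compounds is available to size such a move. Only a modest gain in this assay is therefore expected, and the reading may well stop at the limit again. The expected shift is an at least 1.2-fold lower number from compound 2 to compound 3 (0.09 log units; that floor lies within the scatter), a small move toward stronger inhibition that may not clear the usual scatter. For compound 3 the estimated half-maximal inhibitory concentration is 800 nM, with an expected range from 100 nM to 5000 nM.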

Compound 3, half-maximal inhibitory concentration: 13 nM
Compound 3: middle estimate off by 62-fold (1.79 log units), on the high side, and the stated range ends above it.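

In this assay, 4-methoxythiophen-2-yl in place of 3-methoxythiophen-2-yl on a double-bonded chain carbon bound to a double-bonded chain carbon gives an at least 76-fold lower number from compound 2 to compound 3 (1.88 log units; beyond the scatter). This shows that the two compounds, though built from the same atoms, are far from equal in this assay, so how the methoxy-bearing thiophene is joined at this place matters a great deal, and compound 3, at 13 nM, supplies the only single number among the compounds shown. The step is nevertheless a floor and not a measured size, because compound 2 stands at a limit of the assay and not at a number: the limit of > 1000 nM in this assay, at which 1 of the 3 values shown sits.

The compounds shown leave open whether the methoxy group itself is needed, since neither a 4-hydroxythiophen-2-yl nor a 4-aminothiophen-2-yl stands among them to separate the role of that group from the role of its placement. They also leave open how far the activity of compound 3 would survive a longer chain in place of the double-bonded chain of the shared core.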